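From Fluorine to Methyl on the Pendant Aryl Group

The source may hold more compounds than are shown below. What is called first, only, known or untested is meant among the compounds shown, and "the series" means these compounds.

Of the compounds shown here, two sharing one core have been measured in an assay on membranes from brain for binding affinity to Adrenergic receptor alpha-1 (Rattus norvegicus); on this read-out higher numbers stand for weaker inhibition and lower numbers for stronger inhibition. Compound 1, `CS(=O)(=O)Nc1ccc2nc(CN3CCC(Cc4ccccc4)CC3)[nH]c2c1`, gives 1500 nM in this assay. Compound 2, `Oc1ccc2[nH]c(CN3CCC(Cc4cccc(F)c4)CC3)nc2c1`, gives 520 nM and so stands at the lowest of the two numbers; its nearest neighbour is compound 1, whose number is higher by a margin that goes beyond the usual scatter. Among the measured compounds shown here, the two compounds differ in more than one place, so no single step between them can be read.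

Compound 3, `Cc1ccc(CC2CCN(Cc3nc4cc(O)ccc4[nH]3)CC2)cc1`, has not yet been measured in this assay. It differs from compound 2 by 4-methylphenyl in place of 3-fluorophenyl on a saturated chain carbon bound to a saturated ring carbon. For the measured compounds named here, no measured pair shows what such an exchange does here, so the direction of the step is open. With nothing to point either way, the step of a 1.2-fold higher number from compound 2 to compound 3 (0.06 log units; within the scatter) is expected to stay within the scatter, or at most slightly beyond it in either direction. Compound 3 is therefore estimated at 600 nM in this assay, with a range from 200 nM to 2000 nM.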

Compound 3, half-maximal inhibitory concentration: 830 nM
Estimate against measurement, compound 3: 1.4-fold (0.14 log units) below; the measured number falls inside the stated range.
By their numbers in this assay, from the lowest: compounds 2, 3 and 1 (each within the scatter of the next, the first and the last beyond it).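

In this assay, among the compounds shown here, 4-methylphenyl in place of 3-fluorophenyl on a saturated chain carbon bound to a saturated ring carbon gives a 1.6-fold higher number from compound 2 to compound 3 (0.20 log units; within the scatter), the first step that can be read at a single place. The exchange swaps one group for another with the same count of heavy atoms, and neither group has hydrogen-bond donors or acceptors, so this position tolerates this particular change with no shift that can be told from the usual scatter of the assay. Nothing at hand bears on why the number stays where it does.

For the compounds shown here, compound 1 differs from compound 2 and compound 3 in more than one place, so its steps cannot be read, and the one step that can be read changes the substituent and its place on the aryl ring together, leaving the contribution of each unseparated. On these data alone, whether 4-fluorophenyl or 3-methylphenyl would fall within the same scatter remains open, as does the outcome for an amine or a carboxylic acid on that ring, or for a longer chain in place of the single saturated carbon that carries it.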